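A smaller ring on compound 2, under an open limit

The source may hold more compounds than are shown below. What is called first, only, known or untested is meant among the compounds shown, and "the series" means these compounds.

In a toxicity assay on Vero C1008 cells (Chlorocebus sabaeus) for cytotoxicity, read by CCK-8 assay (on this read-out higher numbers stand for lower toxicity in this test and lower numbers for higher toxicity in this test), compound 2 (`COc1cccc2[nH]c(C(=O)N[C@@H](CC(C)C)C(=O)N[C@H](C#N)C[C@@H]3CCCNC3=O)cc12`) gives > 200000 nM, which is a limit and not a number. Compound 1 (`COc1cccc2[nH]c(C(=O)N[C@@H](CC(C)C)C(=O)N[C@H](C=O)C[C@@H]3CCNC3=O)cc12`) gives > 200000 nM, also a limit. Compound 3 (`CC(C)C[C@H](NC(=O)c1cc2c(OC(F)(F)F)cccc2[nH]1)C(=O)N[C@H](C#N)C[C@@H]1CCCNC1=O`) gives > 100000 nM, again a limit. All three measured compounds therefore stand at limits, and compound 2 cannot be ranked against the other two.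

Compound 4 (`COc1cccc2[nH]c(C(=O)N[C@@H](CC(C)C)C(=O)N[C@H](C#N)C[C@@H]3CCNC3=O)cc12`) differs from compound 2 in one place: 2-oxopyrrolidin-3-yl in place of 2-oxopiperidin-3-yl on a saturated chain carbon, two bonds along the chain from an amide-type nitrogen and a triple-bonded carbon. In words, it carries 2-oxopyrrolidin-3-yl in place of 2-oxopiperidin-3-yl on a saturated chain carbon, two bonds along the chain from an amide-type nitrogen and a triple-bonded carbon.

Within the data shown here, two measured steps bear on this change. The nearer is a step that the two limits leave unreadable from compound 1 to compound 2, where a group with a six-membered non-aromatic ring replaces one with a five-membered non-aromatic ring, the reverse of the ring change here. The other is a step that the two limits leave unreadable from compound 2 to compound 3, with trifluoromethyl in place of methyl on an oxygen on an aromatic ring. Neither has a readable size, so no step beyond the scatter is expected in this assay, in either direction. The expected change is a number no higher from compound 2 to compound 4 (the limit leaves the size open).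

For compound 4 the estimated value is 200000 nM, with an expected range of 100000 nM to 400000 nM.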

Compound 4, half-maximal cytotoxic concentration: > 200000 nM
Compound 4 gave a limit, no number; the forecaster's own chance of this, stated with the estimate: 85%; the middle value sits exactly at the limit.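

In this assay compound 4 gives > 200000 nM, which is a limit and not a number. Its steps from compound 2 and from compound 1 cannot be read: the limit of > 200000 nM in this assay, at which 3 of the 4 values shown sit.

The compounds shown leave open whether 2-oxopyrrolidin-3-yl and 2-oxopiperidin-3-yl, or cyano and formyl, differ at all in this assay.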